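The source may hold more compounds than are shown below. What is called first, only, known or untested is meant among the compounds shown, and "the series" means these compounds.

Measured compounds:
compound 1, `C=C1C[C@]23C[C@@]1(O)CC[C@@H]2c1cccc(C)c1[C@@H]3Cn1cc(-c2ccc(Br)cc2)nn1`: in a functional assay on HL-60 cells (Homo sapiens) for cytotoxicity, read by MTT assay, with a stated time of 4 days (a higher number here means a weaker inhibitor, a lower number a stronger inhibitor), compound 1 gives > 20000 nM, which is a limit of the assay and not a number.
compound 2, `C=C1C[C@]23C[C@@]1(O)CC[C@@H]2c1cccc(C)c1[C@@H]3Cn1cc(-c2ccccn2)nn1`: in this assay compound 2 gives > 20000 nM, again a limit and not a number.
compound 3, `C=C1C[C@]23C[C@@]1(O)CC[C@H]2c1cc(Br)c(O)c(C)c1[C@@H]3Cn1cc(-c2ccc(C(F)(F)F)cc2)nn1`: in this assay compound 3 gives 7380 nM.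

Compound 2 therefore stands at the limit of this assay, together with compound 1 (the limit of > 20000 nM in this assay, at which 2 of the 3 values shown sit). Among the measured compounds shown here, the one step that touches the same place, a step that the two limits leave unreadable from compound 1 to compound 2, has no readable size, since both of its ends are limits.

Compound 4, `C=C1C[C@]23C[C@@]1(O)CC[C@@H]2c1cccc(C)c1[C@@H]3Cn1cc(-c2ccc(C)cc2)nn1`, differs from compound 2 by 4-methylphenyl in place of pyridin-2-yl on an aromatic carbon. For the measured compounds named here, no measured step shows what a 4-methylphenyl group does here. Going by the values given here, compound 3 carries a trifluoromethylphenyl group on a differently substituted core, so its value sets no step to compound 2.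

With nothing to point the other way, compound 4 is expected to remain at the limit of this assay, estimated at 25000 nM within 10000 nM to 60000 nM. The step this estimate means, a step that the limit leaves unreadable from compound 2 to compound 4, is expected to stay unreadable rather than a real shift.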

Compound 4, half-maximal inhibitory concentration: > 20000 nM
Compound 4 ended at the assay's limit; the forecaster's own chance of this, stated with the estimate: 75%; the middle value is on the limit's open side.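

Among the compounds shown here, compound 1, compound 2 and compound 4 all rest at the same limit, which is not a number, so no step among them can be read: the limit of > 20000 nM in this assay, at which 3 of the 4 values shown sit. The compounds shown leave open whether any group at this place on the shared core can shift the result in this assay by a readable amount.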